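A few compounds are considered here, and "the series" means these few. Any claim that something is new, unique, unknown or untested is made for them only; others in the source may bear on it.

Three compounds sharing one core have numbers in a toxicity assay on HepG2 2.2.15 cells (Homo sapiens) for cytotoxicity, read by CellTiter-Glo; a higher number here means that more compound is tolerated, a lower number that less compound is tolerated. Compound 1 `O=C(Nc1cc(F)c(F)c(F)c1)N1Cc2c(-c3ccc(F)cc3F)cnn2CC1C1CC1` gives 32100 nM, and compound 2 `O=C1OC(c2ccccc2)CN1c1cnn2c1CN(C(=O)Nc1cc(F)c(F)c(F)c1)C(C1CC1)C2` gives 7410 nM. Compound 3 `O=C1CC(C(F)(F)F)CN1c1cnn2c1CN(C(=O)Nc1cc(F)c(F)c(F)c1)C(C1CC1)C2` gives 115000 nM, the highest of the three, so it is the best tolerated.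

Compound 4 `O=C1CC(c2ccc(F)cn2)CN1c1cnn2c1CN(C(=O)Nc1cc(F)c(F)c(F)c1)C(C1CC1)C2` differs from compound 3 in one group: 5-fluoropyridin-2-yl in place of trifluoromethyl on a saturated ring carbon. Put simply, 5-fluoropyridin-2-yl stands in place of trifluoromethyl on a saturated ring carbon, which brings in an aromatic ring.

Among the measured compounds shown here, no measured step makes this exact swap, so the evidence is indirect. The varied groups of compound 1 and compound 2 both hold an aromatic ring, and both compounds stand lower than compound 3. The steps show this as a 3.6-fold higher number from compound 1 to compound 3 (0.55 log units; beyond the scatter), which is modest, and a 16-fold higher number from compound 2 to compound 3 (1.19 log units; beyond the scatter), which is large. The third step, a 4.3-fold lower number from compound 1 to compound 2 (0.64 log units; beyond the scatter), shows that the size of such a change depends on the group.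

A modest to large drop in this assay is therefore expected. The estimated change is a 3.8-fold lower number from compound 3 to compound 4 (0.58 log units; beyond the scatter). For compound 4 the estimated value is 30000 nM, with an expected range of 10000 nM to 90000 nM.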

Compound 4, half-maximal cytotoxic concentration: 38500 nM
For compound 4 the middle estimate is 1.3-fold (0.11 log units) below the measured one; low and high end bracket the measured number.
By their numbers in this assay, from the lowest: compound 2; then compounds 1 and 4 (each within the scatter of the next); then compound 3.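

Among the compounds shown here, this is the first comparison in which the lactam ring stays the same and only the group on its saturated ring carbon changes: in this assay, the swap gives a 3.0-fold lower number from compound 3 to compound 4 (0.48 log units; beyond the scatter) and so shows that this carbon alone can shift the number. The earlier steps shown here replaced the whole group on the aromatic carbon, so they could not separate this carbon from the rest of that group. Nothing given here accounts for the size of this step.

The compounds shown leave open whether the lower number comes from bringing in the aromatic ring or from losing trifluoromethyl. They also do not show how a simple methyl, an amine or a carboxylic acid on this same carbon would compare with either group.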